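The source may hold more compounds than are shown below. What is called first, only, known or untested is meant among the compounds shown, and "the series" means these compounds.

In a functional assay on A549 cells (Homo sapiens) for cytotoxicity, read by MTT assay, with a stated time of 24 h (a lower number here means a stronger inhibitor, a higher number a weaker inhibitor), compound 1 `Nc1cccn2cc(Cc3ccccc3)c(=O)nc12` gives 98000 nM. Compound 2 `O=c1nc2ccccn2cc1Cc1ccc(F)cc1` reads > 1000000 nM, which is a limit of the assay and not a number. Compound 3 `O=c1nc2ccccn2cc1Cc1ccccc1` differs from compound 2 in one place: hydrogen in place of fluoro on an aromatic carbon. Among the measured compounds shown here, no measured pair shows this change alone, and compound 1 at 98000 nM is the only true number to go by. A modest move towards a stronger inhibitor is therefore expected, an estimated at least 2.5-fold lower number from compound 2 to compound 3 (0.39 log units; beyond the scatter). For compound 3, the expected value is 400000 nM, with an estimated range of 100000 nM to 1500000 nM.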

Compound 3, half-maximal inhibitory concentration: 104000 nM
For compound 3 the middle estimate is 3.8-fold (0.59 log units) above the measured one; the range from low to high includes it.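

On an aromatic carbon para to a large group, hydrogen in place of fluoro gives an at least 9.6-fold lower number from compound 2 to compound 3 (0.98 log units; beyond the scatter). In this assay, from the compounds shown here alone, compound 2 reads > 1000000 nM, which is a limit and not a number, so the full size of this step stays unknown: the limit of > 1000000 nM in this assay, at which 1 of the 3 values shown sits. Elsewhere on the shared core, hydrogen in place of amino gives a 1.1-fold higher number from compound 1 to compound 3 (0.03 log units; within the scatter), so this swap shows no difference beyond the scatter.

Going by these compounds, whether chloro or methoxy at the fluoro position would read like compound 2 or like compound 3 stays open. So does what a carboxylic acid would do in place of the amino of compound 1.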